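Chloro to Trifluoromethyl: What to Expect

A few compounds are considered here, and "the series" means these few. Any claim that something is new, unique, unknown or untested is made for them only; others in the source may bear on it.

Values in an ADME assay on Caco-2 cells (Homo sapiens) for permeability, in the apical to basolateral direction, at pH 7.4; on this read-out lower numbers stand for lower permeability and higher numbers for higher permeability:
- Compound 1 `O=C(N[C@H]1CN(S(=O)(=O)c2ccccc2)C[C@@H]1C(=O)N[C@H]1CCCNC1)c1cc(-c2ccccc2)on1`: 0.12 10^-6 cm/s
- Compound 2 `O=C(N[C@H]1CN(S(=O)(=O)c2ccccc2)C[C@@H]1C(=O)N[C@H]1CCCNC1)c1nnc(-c2ccc(F)cc2)s1`: < 0.03 10^-6 cm/s, a limit of the assay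
- Compound 3 `Cc1oc(-c2ccc(Cl)cc2)nc1C(=O)N[C@H]1CN(S(=O)(=O)c2ccccc2)C[C@@H]1C(=O)N[C@H]1CCCNC1`: 0.14 10^-6 cm/s

Compound 3, at 0.14 10^-6 cm/s, lies within the usual scatter of compound 1, so the two cannot be told apart. Compound 4 `Cc1oc(-c2ccc(C(F)(F)F)cc2)nc1C(=O)N[C@H]1CN(S(=O)(=O)c2ccccc2)C[C@@H]1C(=O)N[C@H]1CCCNC1` carries trifluoromethyl in place of chloro on an aromatic carbon, para to a large group (trifluoromethyl in place of chloro on an aromatic carbon). Within the data shown here, the only measured step, an at least 4.0-fold lower number from compound 1 to compound 2 (0.60 log units; beyond the scatter), exchanged a whole ring-bearing group on a carbonyl carbon, so it is a loose guide to this smaller change. Among the measured compounds shown here, no measured step touches this position. The expected change in this assay is a 1.2-fold lower number from compound 3 to compound 4 (0.07 log units; within the scatter), which stays within the scatter. Compound 4 is estimated at 0.12 10^-6 cm/s, with an expected range from 0.05 10^-6 cm/s to 0.28 10^-6 cm/s.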

Compound 4, apparent permeability in the Caco-2 assay: 0.1 10^-6 cm/s
Compound 4: the middle estimate sits 1.2-fold (0.08 log units) above what was measured, within the range that was stated.
By their numbers in the Caco-2 assay, from the lowest: compounds 4, 1 and 3 (each within the scatter of the next). At a limit, below all of these: compound 2.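

Only compounds 3 and 4 differ at this aromatic carbon. In the Caco-2 assay compound 3 gives 0.14 10^-6 cm/s and compound 4 gives 0.1 10^-6 cm/s, and replacing chloro with trifluoromethyl gives a 1.4-fold lower number from compound 3 to compound 4 (0.15 log units; within the scatter), so the two groups cannot be told apart on permeability. In a physicochemical assay for solubility, at pH 7.4 (on this read-out lower numbers stand for lower solubility and higher numbers for higher solubility), compound 3 gives 15000 nM and compound 4 gives 13000 nM, and the same exchange gives a 1.2-fold lower number from compound 3 to compound 4 (0.06 log units; within the scatter), so neither read-out separates them. Nothing measured here bears on why the two groups read alike.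

As far as these compounds go, it remains open whether an amine or a carboxylic acid on this aromatic carbon would move either read-out beyond the scatter. From the compounds shown here alone, it is also open whether the same exchange would behave alike with the other ring-bearing groups of compounds 1 and 2.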